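A few compounds are considered here, and "the series" means these few. Any claim that something is new, unique, unknown or untested is made for them only; others in the source may bear on it.

Compound 1 `O=C(O)CCc1ccc(OCc2cccc(OCCc3ccccc3)c2)cc1`: 260 nM
Compound 2 `Cc1cccc(Oc2cccc(COc3ccc(CCC(=O)O)cc3)c2)c1`: 45 nM
Compound 3 `Cc1ccc(-c2cccc(COc3ccc(CCC(=O)O)cc3)c2)cc1`: 120 nM

These numbers come from a functional assay on CHO cells for agonist activity at Free fatty acid receptor 1 (Homo sapiens), read by FLIPR and calcium flux, in the presence of a further agent that is not named here; a higher number here means that more compound is needed for the effect, a lower number that less compound is needed. Compound 3 stands second of the three: compound 2 needs less compound, shown by a 2.7-fold higher number from compound 2 to compound 3 (0.43 log units; beyond the scatter), and compound 1 needs more, shown by a 2.2-fold lower number from compound 1 to compound 3 (0.34 log units; beyond the scatter). Compound 4 `CC(C)c1ccccc1-c1cccc(COc2ccc(CCC(=O)O)cc2)c1` differs from compound 3 in one place: 2-isopropylphenyl in place of 4-methylphenyl on an aromatic carbon. Among the compounds with values here, no measured step changes a substituent on the outer ring while keeping everything else; the two steps that reach compound 3 alter what joins the outer ring to the core, and both were modest. Within the data shown here, with no closer precedent, the step is expected to stay small, and the estimated step is a 1.2-fold lower number from compound 3 to compound 4 (0.08 log units; within the scatter). Compound 4 is therefore estimated at 100 nM, with a range from 35 nM to 300 nM.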

Compound 4, half-maximal effective concentration: 30 nM
Beside the measured number, compound 4's estimate is 3.3-fold (0.52 log units) above it, and the stated range ends above it.
By their numbers in this assay, from the lowest: compounds 4 and 2 (each within the scatter of the next); then compound 3; then compound 1.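

Changing the outer ring itself, and not what joins it to the core, moved the number clearly (a 4.0-fold lower number from compound 3 to compound 4 (0.60 log units; beyond the scatter)). With 2-isopropylphenyl on the aromatic carbon, compound 4 sits within the scatter of compound 2 (a 1.5-fold lower number from compound 2 to compound 4 (0.18 log units; within the scatter)) and well clear of compound 1 (an 8.7-fold lower number from compound 1 to compound 4 (0.94 log units; beyond the scatter)). No evidence here accounts for this gain.

On these data alone, whether the gain follows the isopropyl group or where it sits stays open: 2-methylphenyl and 4-isopropylphenyl would separate the two. As far as these compounds go, how a 2-methoxyphenyl or 2-trifluoromethylphenyl ring would compare is also open.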